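The source may report more compounds than this note shows. Statements on the series, on what has been measured and on what is new or still open speak of the compounds shown alone.

Values in a functional assay on A549 cells (Homo sapiens) for inhibition, read by MTT assay, with a stated time of 72 h; a higher number here means a weaker inhibitor, a lower number a stronger inhibitor:
- compound 1 `COc1ccccc1-n1c(-c2coc3cc(C)c(Cl)cc3c2=O)nc(-c2ccccc2)c1-c1ccccc1` gives 12500 nM
- compound 2 `Cc1cc2occ(-c3nc(-c4ccccc4)c(-c4ccccc4)n3-c3ccc(Cl)c(Cl)c3)c(=O)c2cc1Cl` gives 6250 nM
- compound 3 `Cc1cc2occ(-c3nc(-c4ccccc4)c(-c4ccccc4)n3-c3ccccc3Cl)c(=O)c2cc1Cl` gives 12500 nM

Compound 3 at 12500 nM sits level with compound 1 and within the scatter of compound 2. The next analogue, compound 4 `Cc1cc2occ(-c3nc(-c4ccccc4)c(-c4ccccc4)n3-c3cccc(Cl)c3)c(=O)c2cc1Cl`, differs from it as follows: 3-chlorophenyl in place of 2-chlorophenyl on an aromatic nitrogen. The closest evidence is the set of measured changes on the same aromatic nitrogen: a 2.0-fold lower number from compound 1 to compound 2 (0.30 log units; within the scatter), no change at the digits printed from compound 1 to compound 3 (within the scatter) and a 2.0-fold higher number from compound 2 to compound 3 (0.30 log units; within the scatter). None of these leaves the scatter, so no step beyond the scatter is expected in this assay, and no direction is favoured with confidence. The expected step is a 1.4-fold lower number from compound 3 to compound 4 (0.14 log units; within the scatter). Compound 4 is estimated at 9000 nM, with an expected range of 4000 nM to 20000 nM.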

Compound 4, half-maximal inhibitory concentration: 25000 nM
For compound 4 the middle estimate is 2.8-fold (0.44 log units) below the measured one; the measured number lies above the stated range.
By their numbers in this assay, from the lowest: compounds 2, 1, 3 and 4 (each within the scatter of the next, the first and the last beyond it).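

In this assay, within the data shown here, the 3,4-dichlorophenyl group on the aromatic nitrogen gives the first step beyond the scatter, with hydrogen in place of one chloro on an aromatic carbon (a 4.0-fold higher number from compound 2 to compound 4 (0.60 log units; beyond the scatter)). Shifting the chloro, 3-chlorophenyl in place of 2-chlorophenyl (a 2.0-fold higher number from compound 3 to compound 4 (0.30 log units; within the scatter)), and 3-chlorophenyl in place of 2-methoxyphenyl (a 2.0-fold higher number from compound 1 to compound 4 (0.30 log units; within the scatter)) both stay within the scatter. Nothing available accounts for the step beyond the scatter.

Open, from the compounds shown here alone, is how 4-chlorophenyl, or a phenyl bearing an amine or a carboxylic acid, would read on the same aromatic nitrogen.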